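Swapping a Thiophene for a Chlorophenyl in Compound 4

The source may hold more compounds than are shown below. What is called first, only, known or untested is meant among the compounds shown, and "the series" means these compounds.

Three compounds sharing one core were tested in a functional assay on KM12 cells (Homo sapiens) for inhibition, read by sulforhodamine B assay, with a stated time of 48 h, tested at 10 uM; a higher number here means more inhibition at the concentration tested (going by the name of the read-out), a lower number less inhibition. Compound 1 `c1ccc2c(-c3cn4ccnc4c(-c4ccc5ncn(C6CCCCC6)c5c4)n3)cccc2c1` gives 11.1%, compound 2 `Fc1ccc(-c2cn3ccnc3c(-c3ccc4ncn(C5CCCCC5)c4c3)n2)cc1` gives 3.49%, and compound 3 `c1cn2cc(-c3ccsc3)nc(-c3ccc4ncn(C5CCCCC5)c4c3)c2n1` gives 15.4%. Compound 3 has the highest of the three numbers: its gap to compound 1 lies within the scatter, while a number 11.9 percentage points higher from compound 2 to compound 3 (beyond the scatter). Compound 4 `Clc1ccc(-c2cn3ccnc3c(-c3ccc4ncn(C5CCCCC5)c4c3)n2)cc1` differs from compound 3 in one place: 4-chlorophenyl in place of thiophen-3-yl on an aromatic carbon. This change is close to the reverse of the step from compound 2 to compound 3, because a number 11.9 percentage points higher from compound 2 to compound 3 (beyond the scatter) covered a swap of a six-membered carbon-only ring bearing a halogen for the thiophen-3-yl. A modest drop is therefore expected, with a number 9.4 percentage points lower from compound 3 to compound 4 (within the scatter). Compound 4 is estimated to show 6%, within a range from -4% to 16%.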

Compound 4, a percentage reported as inhibition, at one concentration (the size of the read-out at that concentration, not a potency): 10.6%
For compound 4 the middle estimate is 4.6 percentage points below the measured one, and the stated range covers the measured number.
By their numbers in this assay, from the lowest: compounds 2, 4, 1 and 3 (each within the scatter of the next, the first and the last beyond it).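

In this assay, a halogen-bearing phenyl ring at this position need not fall beyond the scatter from thiophen-3-yl: 4-chlorophenyl gives a number 4.8 percentage points lower from compound 3 to compound 4 (within the scatter), and against naphthalen-1-yl it gives a number 0.5 percentage points lower from compound 1 to compound 4 (within the scatter). Exchanging only the halogen, chloro for fluoro, gives a number 7.1 percentage points higher from compound 2 to compound 4 (within the scatter), so this single-atom change cannot be separated from the scatter. No measurement available here explains these numbers.

Every group shown at this position is an aromatic ring, so it remains open how an amine or a carboxylic acid there would read out.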